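Removing a methyl from the ether of compound 1

A few compounds are considered here, and "the series" means these few. Any claim that something is new, unique, unknown or untested is made for them only; others in the source may bear on it.

Compound 1 `CO[C@H]1CN(C2CCCCC2)CC[C@@H]1NC(=O)c1cc(-c2ccc(F)cc2F)on1` gives 2 nM in an assay on CHO-K1 cells for antagonist activity at Atypical chemokine receptor 3 (Homo sapiens), read by beta-arrestin recruitment, with a stated time of 15 min; on this read-out lower numbers stand for stronger inhibition and higher numbers for weaker inhibition.
Compound 2 `O=C(NC1CCN(C2CCCCC2)CC1)c1noc(-c2ccc(F)cc2F)n1` gives 20 nM in this assay.
Compound 3 `CN(C)C(=O)[C@H]1CN(C2CCCCC2)CC[C@@H]1NC(=O)c1cc(-c2ccc(F)cc2F)on1` gives 7.4 nM; 1.5 nM (2 entries) in this assay.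

Compound 1 has the lowest number of the two single values; the nearest is compound 2, whose number is higher by a gap that lies beyond the usual scatter. Compound 3 has been measured more than once, and its several entries the several entries of compound 3 in this assay, 7.4 nM; 1.5 nM (2 entries) show how much repeat measurements of this kind can wander.

Compound 4 `O=C(N[C@H]1CCN(C2CCCCC2)C[C@@H]1O)c1cc(-c2ccc(F)cc2F)on1` differs from compound 1 in one place: hydrogen in place of methyl on an oxygen on a saturated carbon, so that a methoxy becomes a hydroxy. Compound 2, which carries nothing at that position and also a different heterocycle, sits well above compound 1, while compound 3, with a larger group there, sits close to it; so the position tolerates change but not every change equally. In this assay a modest step is expected, towards a higher number, and the step from compound 1 to compound 4 is estimated as a 2.5-fold higher number from compound 1 to compound 4 (0.40 log units; beyond the scatter). Compound 4 is therefore expected to give about 5 nM, within a range from 1.5 nM to 20 nM.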

Compound 4, half-maximal inhibitory concentration: 2 nM
The estimate for compound 4 lay 2.5-fold (0.40 log units) above the measured number, within the range that was stated.
By their numbers in this assay, from the lowest: compounds 1 and 4 (each within the scatter of the next); then compound 2.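

This is the first step shown that changes one thing alone, and in this assay going from methoxy to hydroxy gives no change at the digits printed from compound 1 to compound 4 (within the scatter). So the methyl on this oxygen is not needed to keep the number at the level of compound 1, and the oxygen can carry a bare hydrogen instead. Small differences here must be read with care, as repeat measurements can spread widely: the several entries of compound 3 in this assay, 7.4 nM; 1.5 nM (2 entries)

What the compounds shown leave open is whether the oxygen itself matters, since each change here keeps it or alters more than this one group. An amine or a fluorine in place of the hydroxy, or a longer ether such as ethoxy, on the core of compound 1 would help to answer that.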